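Aryl for benzyl on the ring nitrogen: compound 4

The source may report more compounds than this note shows. Statements on the series, on what has been measured and on what is new or still open speak of the compounds shown alone.

In a functional assay on NCI-H460 cells (Homo sapiens) for antiproliferative activity, read by CCK-8 assay, with a stated time of 72 h, tested at 8 uM (a lower number here means a weaker effect, a higher number a stronger effect of the compound at the concentration tested), compound 2 `Nc1ccccc1NC(=O)c1ccc(Cn2cnc3c(NCc4ccccc4)nc(Cl)nc32)cc1` gives 61.2%. That number is the second highest of the three measured. Compound 1 `CCC(C)n1cnc2c(NCc3ccc(C(=O)Nc4ccccc4N)cc3)nc(Cl)nc21` gives 67.7%, and the gap between compound 2 and compound 1 lies within the scatter, so no order between the two is claimed. Compound 3 `Nc1ccccc1NC(=O)/C=C/c1ccc(COCNc2nc(Nc3cccc(Cl)c3)c3ncn(C4CCCC4)c3n2)cc1` gives 46.1%, a number that sits beyond the scatter below the value of compound 2.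

Compound 4 `Nc1ccccc1NC(=O)c1ccc(Cn2cnc3c(Nc4cccc(OC(F)(F)F)c4)nc(Cl)nc32)cc1` differs from compound 2 in one place: 3-(trifluoromethoxy)phenyl in place of benzyl on a nitrogen on an aromatic ring. Among the compounds with values here, no measured pair separates benzyl from 3-(trifluoromethoxy)phenyl on a nitrogen on an aromatic ring, so the size of this step is not known from the numbers at hand. Compound 3 differs from compound 2 in several places at once, and the comparison of their two values is not a step of this kind. The expected step is small, in either direction, and not beyond the scatter: the estimate means a change from compound 2 to compound 4 of a number 1.2 percentage points lower from compound 2 to compound 4 (within the scatter). Compound 4 is therefore estimated at 60%, with a range from 40% to 78%.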

Compound 4, a percentage reported as inhibition, at one concentration (the size of the read-out at that concentration, not a potency): 62.4%
Beside the measured number, compound 4's estimate is 2.4 percentage points below it, and the stated range covers the measured number.
By their numbers in this assay, from the lowest: compound 3; then compounds 2, 4 and 1 (each within the scatter of the next).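

Within the data shown here, replacing benzyl with 3-(trifluoromethoxy)phenyl on a nitrogen on an aromatic ring gives a number 1.2 percentage points higher from compound 2 to compound 4 (within the scatter) in this assay, the first step that changes a single place. Among these compounds, at the concentration tested, this position therefore takes an aryl group carrying oxygen and fluorine atoms that benzyl lacks, with no shift in the read-out beyond the scatter, which the earlier compounds, differing in several places, could not show. Nothing at hand bears on the reason for this result.

Still open, from the compounds shown here alone, is whether this position stays as permissive for groups of a different kind, such as a longer alkyl chain, a morpholine or a carboxylic acid. A read-out at one concentration also leaves open whether compound 2 and compound 4 would match across a full concentration series.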